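The source may hold more compounds than are shown below. What is called first, only, known or untested is meant among the compounds shown, and "the series" means these compounds.

Measured so far in a functional assay on CRL2813 cells (Homo sapiens) for cytotoxicity, read by sulforhodamine B assay, with a stated time of 5 days; a lower number here means a stronger inhibitor, a higher number a weaker inhibitor:
compound 1, `O=C(Nc1ccccc1C(=O)O)N[C@H]1CC[C@@H](Oc2ccc(F)cc2)CC1`: > 20000 nM
compound 2, `O=C(Nc1ccc([N+](=O)[O-])cc1)N[C@H]1CC[C@H](Oc2ccc(F)cc2)CC1`: 2300 nM
compound 3, `O=C(Nc1cccc(C(F)(F)F)c1)N[C@H]1CC[C@H](Oc2ccc(Cl)cc2)CC1`: 2000 nM.

For compound 1 the value > 20000 nM is a limit of this assay and not a number; see (the limit of > 20000 nM in this assay, at which 1 of the 3 values shown sits). That leaves two numbers. Among them compound 2 sits at the higher end, yet its nearest neighbour compound 3 lies only a small distance below it, within the usual scatter, so no order between compound 2 and compound 3 can be read from this assay. Among the measured compounds shown here, no pair of measured compounds differs in a single place, so no measured step gives a scale for what one change on the aryl urea end does here.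

Compound 4, `Cc1ccccc1NC(=O)N[C@H]1CC[C@H](Oc2ccc(F)cc2)CC1`, is the next compound for this assay. Against compound 2 the change is 2-methylphenyl in place of 4-nitrophenyl on an amide-type nitrogen. For the measured compounds named here, with no single-point step available, the size of this move can only be guessed; the expected step from compound 2 to compound 4 is a 1.5-fold higher number from compound 2 to compound 4 (0.18 log units; within the scatter), which is not expected to reach clearly beyond the scatter. Compound 4 is therefore estimated at 3500 nM in this assay, with a range from 1200 nM to 12000 nM.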

Compound 4, half-maximal inhibitory concentration: > 20000 nM
Compound 4 ended at the assay's limit; the forecaster's own chance of this, stated with the estimate: 15%; middle value at least 5.7-fold (0.75 log units) from the limit.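

In this assay compound 4 gives > 20000 nM and this is a limit of the assay, not a number. Placing 2-methylphenyl in place of 4-nitrophenyl on an amide-type nitrogen gives the first measured single-place step in the series, an at least 8.6-fold higher number from compound 2 to compound 4 (0.93 log units; beyond the scatter), so the aryl group at this position is not interchangeable in this cytotoxicity read-out, and the swap of this one group alone is enough to move a compound clearly beyond the scatter. The step has a floor but no measured upper end, and its top value is the same limit seen earlier in the set: the limit of > 20000 nM in this assay, at which 2 of the 4 values shown sit.

This one pair does not separate the loss of 4-nitrophenyl from the arrival of 2-methylphenyl, and compound 1 and compound 3 each differ from compound 2 in more than one place, so neither gives a reading of this change. A plain phenyl, or a phenyl carrying a nitrile or an amine, on the same nitrogen would be needed to show which of the two groups governs the step in this assay.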